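The compounds below may be only part of what the source reports. "The series", "measured", "known", "first", "only" and "open" are said of these compounds alone.

Of the compounds shown here, three have so far been tested in a functional assay on PC-3 cells (Homo sapiens) for cytotoxicity, read by MTT assay, with a stated time of 72 h; on this read-out lower numbers stand for stronger inhibition and higher numbers for weaker inhibition. Compound 1 `Cc1cc(=O)n(-c2cccc(F)c2)nc1C(=O)Nc1ccc(Oc2ncnc3[nH]ccc23)c(F)c1` gives 6680 nM in this assay. Compound 2 `Cc1cc(=O)n(-c2ccc(Br)cc2F)nc1C(=O)Nc1ccc(Oc2ncnc3[nH]ccc23)c(F)c1` gives 13300 nM in this assay, and compound 3 `Cc1cc(=O)n(-c2ccc(Br)cc2F)nc1C(=O)Nc1ccc(Oc2ncnc3c2ccn3C)cc1` gives 18800 nM in this assay. Compound 1 and compound 2 share one core and differ only in the group carried on an aromatic nitrogen: 3-fluorophenyl in place of 4-bromo-2-fluorophenyl on an aromatic nitrogen. That change gave a 2.0-fold lower number from compound 2 to compound 1 (0.30 log units; within the scatter). Compound 3 carries the same 4-bromo-2-fluorophenyl group as compound 2 but sits on a different core; the difference between the two cores is not broken down here. Compound 3 stands at the highest of the three numbers, with compound 2 nearest to it within the scatter and compound 1 furthest, beyond the scatter.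

A fourth compound, compound 4 `Cc1cc(=O)n(-c2cccc(F)c2)nc1C(=O)Nc1ccc(Oc2ncnc3c2ccn3C)cc1`, has not yet been measured. It is related to compound 3 by the same change that leads from compound 2 to compound 1: 3-fluorophenyl in place of 4-bromo-2-fluorophenyl on an aromatic nitrogen. The place of the change reads the same in both pairs, so this is the same change made on the core of compound 3. If it behaves there as it did on the core of compound 2, the step expected is a 2.0-fold lower number from compound 3 to compound 4 (0.30 log units; within the scatter), resting on a 2.0-fold lower number from compound 2 to compound 1 (0.30 log units; within the scatter). Because compound 3 stands at 18800 nM, compound 4 is expected to give about 9500 nM in this assay, most likely between 4500 nM and 20000 nM.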

Compound 4, half-maximal inhibitory concentration: > 60000 nM
Compound 4 was reported as a limit; the forecaster's own chance of this, stated with the estimate: 10%; middle value at least 6.3-fold (0.80 log units) away from the limit.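

In this assay compound 4 gives > 60000 nM, which is a limit of the assay and not a number. Read against compound 3, this limit still gives a clear result, an at least 3.1-fold higher number from compound 3 to compound 4 (0.50 log units; beyond the scatter), so putting 3-fluorophenyl in place of 4-bromo-2-fluorophenyl on the aromatic nitrogen did not behave the same way on the two cores: the same change on two cores in this assay, a 2.0-fold lower number (0.30 log units; within the scatter) from compound 2 to compound 1 and an at least 3.1-fold higher number (0.50 log units; beyond the scatter) from compound 3 to compound 4, at least 6.3-fold (0.80 log units) apart, beyond the scatter of two such steps. Going by these compounds alone, this shows that, for these four compounds, the outcome of the change on one core could not be carried over to the other, but it rests on only one pair per core, it does not give the full size of the step on the core of compound 3, and it does not show what in the cores sets the two steps apart.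

The compounds shown leave open which of the differences between the core of compound 2 and the core of compound 3 matters for this split. They also leave open how each core would respond to other groups on the same nitrogen, such as a plain phenyl or a cyclohexyl group, and so whether the split extends beyond this single pair of groups.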